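This account rests on a few compounds, and the source may have more. Where it says the series, first, only, none or still open, it means among the compounds named here.

Working notes on the shared core. Compound 1 `CC(C)c1onc(-c2c(Cl)cccc2Cl)c1COc1ccc(-c2nc3ccc(C(=O)O)cc3n2-c2ccc(F)cc2)cc1` bears a 4-fluorophenyl on the aromatic nitrogen, compound 2 `CC(=O)N1CCC(n2c(-c3ccc(OCc4c(-c5c(Cl)cccc5Cl)noc4C(C)C)cc3)nc3ccc(C(=O)O)cc32)CC1` a 1-acetylpiperidin-4-yl at the same place. In an assay on HEK-293T cells for antagonist activity at vitamin D3 receptor (Homo sapiens), read by a luciferase reporter, with a stated time of 24 h (a higher number here means a weaker inhibitor, a lower number a stronger inhibitor), compound 1 gives 2410 nM. For compound 2 this assay reports only a limit, > 10000 nM. Where compound 2 stands is thus known only as a limit, as recorded in the limit of > 10000 nM in this assay, at which 1 of the 2 values shown sits. Among the measured compounds shown here, the single measured step, an at least 4.1-fold higher number from compound 1 to compound 2 (0.61 log units; beyond the scatter), is the sole comparison available.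

Compound 3 `CC(=O)C1CCC(Cn2c(-c3ccc(OCc4c(-c5c(Cl)cccc5Cl)noc4C(C)C)cc3)nc3ccc(C(=O)O)cc32)CC1` differs from compound 2 in one place: (4-acetylcyclohexyl)methyl in place of 1-acetylpiperidin-4-yl on an aromatic nitrogen. For the measured compounds named here, no measured step covers this exact exchange; the step that bears on the same position of the core is an at least 4.1-fold higher number from compound 1 to compound 2 (0.61 log units; beyond the scatter), in which the move from 4-fluorophenyl to 1-acetylpiperidin-4-yl ended at the limit. With compound 2 already at that limit, the step is expected to be small and probably not readable in this assay, a step that the limit leaves unreadable from compound 2 to compound 3. Compound 3 is estimated at 15000 nM, within 4000 nM to 60000 nM, and is expected most likely to come back as a limit once more.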

Compound 3, half-maximal inhibitory concentration: > 10000 nM
Compound 3: only a limit was reported; the forecaster's own chance of this, stated with the estimate: 70%; the middle value is on the limit's open side.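

Compound 3 is reported only as a limit (> 10000 nM) in this assay. Exchanging the 4-fluorophenyl on the aromatic nitrogen for (4-acetylcyclohexyl)methyl gives an at least 4.1-fold higher number from compound 1 to compound 3 (0.61 log units; beyond the scatter) and so shows that the loss seen with the 1-acetylpiperidin-4-yl group is not confined to that one group, since a second group built on a six-membered non-aromatic ring, this time of carbon only, also leaves the compound at the limit, while compound 1 remains the only one of the three with a measured number. The step between the two limits cannot be read, so the two non-aromatic groups cannot be ranked against each other, and the exchange of the ring nitrogen for carbon has no readable effect here: the limit of > 10000 nM in this assay, at which 2 of the 3 values shown sit.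

Open, as far as these compounds go, is how far above the limit compound 2 and compound 3 lie, and whether the acetyl group or the non-aromatic ring accounts for the loss. A phenyl carrying an acetyl group, or a plain cyclohexyl, on the aromatic nitrogen would separate those two parts of the change.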